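Exchanging One Imidazole Group for Another

The source may report more compounds than this note shows. Statements on the series, on what has been measured and on what is new or still open speak of the compounds shown alone.

The compounds here share one core and differ only in a group on a saturated chain carbon bound to a saturated ring carbon. In a functional assay on HUVEC cells (Homo sapiens), read by scintillation counting and thymidine incorporation, with a stated time of 24 h (a lower number here means a stronger inhibitor, a higher number a weaker inhibitor), compound 1 `CCC(C)n1ncn(-c2ccc(N3CCN(c4ccc(OC[C@@H]5CO[C@@](CBr)(c6ccc(Cl)cc6Cl)O5)cc4)CC3)cc2)c1=O` gives 569 nM with bromo at that place. Compound 2 `CCC(C)n1ncn(-c2ccc(N3CCN(c4ccc(OC[C@@H]5CO[C@@](CN6CCN(C)CC6)(c6ccc(Cl)cc6Cl)O5)cc4)CC3)cc2)c1=O` gives 396 nM with 4-methylpiperazin-1-yl there. Compound 3 `CCc1nccn1C[C@@]1(c2ccc(Cl)cc2Cl)OC[C@@H](COc2ccc(N3CCN(c4ccc(-n5cnn(C(C)CC)c5=O)cc4)CC3)cc2)O1` gives 224 nM with 2-ethyl-1H-imidazol-1-yl there. The standing of compound 3 is mixed: the data show a 1.8-fold lower number from compound 2 to compound 3 (0.25 log units; within the scatter) and also a 2.5-fold lower number from compound 1 to compound 3 (0.40 log units; beyond the scatter) in the other comparison.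

Compound 4 `CCC(C)n1ncn(-c2ccc(N3CCN(c4ccc(OC[C@@H]5CO[C@@](Cn6cc(C)nc6C)(c6ccc(Cl)cc6Cl)O5)cc4)CC3)cc2)c1=O` puts 2,4-dimethyl-1H-imidazol-1-yl in place of 2-ethyl-1H-imidazol-1-yl at the same place, and 2,4-dimethyl-1H-imidazol-1-yl in place of 2-ethyl-1H-imidazol-1-yl on a saturated chain carbon bound to a saturated ring carbon sums up a change that keeps the same atoms, joined differently. All three measured steps change this place too. Alongside the two above stands a 1.4-fold lower number from compound 1 to compound 2 (0.16 log units; within the scatter) as the third, so the largest step seen is modest. Among the compounds with values here, no measured pair compares two imidazole groups, which makes these steps only a loose guide. No step beyond the scatter is expected, and a 1.1-fold higher number from compound 3 to compound 4 (0.03 log units; within the scatter) is the estimated step. Compound 4 is estimated at 240 nM with 110 nM to 520 nM as the expected range.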

Compound 4, half-maximal inhibitory concentration: 492 nM
The estimate for compound 4 lay 2.1-fold (0.31 log units) below the measured number; the range from low to high includes it.
By their numbers in this assay, from the lowest: compounds 3, 2, 4 and 1 (each within the scatter of the next, the first and the last beyond it).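

Two imidazole groups built from the same atoms are not interchangeable on this saturated chain carbon: in this assay, the rearrangement from 2-ethyl-1H-imidazol-1-yl to 2,4-dimethyl-1H-imidazol-1-yl gives a 2.2-fold higher number from compound 3 to compound 4 (0.34 log units; beyond the scatter), a modest step but one that clears the usual scatter. Carrying an imidazole at this place is therefore not enough on its own to separate a compound from the others, as a 1.2-fold higher number from compound 2 to compound 4 (0.09 log units; within the scatter) and a 1.2-fold lower number from compound 1 to compound 4 (0.06 log units; within the scatter) both stay within the scatter, leaving 2,4-dimethyl-1H-imidazol-1-yl unresolved from 4-methylpiperazin-1-yl and from bromo. No measurement available here explains the difference between the two imidazole groups.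

The compounds shown leave open whether the difference follows the ethyl group or the extra methyl group, a question that 2-methyl-1H-imidazol-1-yl, which differs from each of them in a single feature, could help to settle. A longer chain in the same spot, as in 2-propyl-1H-imidazol-1-yl, could show whether the number keeps falling as the chain grows or whether the trend stops at ethyl.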